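Quinazoline cinnamamides: from nitrophenyl toward trimethoxyphenyl

The compounds below may be only part of what the source reports. "The series", "measured", "known", "first", "only" and "open" are said of these compounds alone.

Compound 1 `O=C(/C=C/c1ccc([N+](=O)[O-])cc1)Nc1cc2c(Nc3ccc(F)c(Cl)c3)ncnc2cc1O[C@H]1CCOC1`: 27400 nM
Compound 2 `COc1cc2ncnc(Nc3ccc(F)c(Cl)c3)c2cc1NC(=O)/C=C/c1ccc(F)cc1Cl`: "not determined" (no result reported)

Among the measured compounds shown here, in a functional assay on HeLa cells (Homo sapiens) for cytotoxicity, read by MTT assay, with a stated time of 72 h (a lower number here means a stronger inhibitor, a higher number a weaker inhibitor), compound 1 gives 27400 nM, the only number in hand, so compound 1 stands alone and cannot be ranked. Compound 2 gives "not determined" (no result reported) in this assay. Compound 3 `COc1cc(/C=C/C(=O)Nc2cc3c(Nc4ccc(F)c(Cl)c4)ncnc3cc2O[C@H]2CCOC2)cc(OC)c1OC` differs from compound 1 in one place: 3,4,5-trimethoxyphenyl in place of 4-nitrophenyl on a double-bonded chain carbon bound to a double-bonded chain carbon. For the measured compounds named here, with no measured step to lean on, only a modest shift is expected, likely toward a somewhat stronger inhibitor but possibly none beyond the scatter. The expected step from compound 1 to compound 3 in this assay is a 1.8-fold lower number from compound 1 to compound 3 (0.26 log units; within the scatter). Compound 3 is thus estimated at 15000 nM, ranging from 4000 nM to 60000 nM.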

Compound 3, half-maximal inhibitory concentration: 24500 nM
Compound 3: the middle estimate sits 1.6-fold (0.21 log units) below what was measured; the measured number falls inside the stated range.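

In this assay, putting 3,4,5-trimethoxyphenyl in place of 4-nitrophenyl on a double-bonded chain carbon bound to a double-bonded chain carbon gives a 1.1-fold lower number from compound 1 to compound 3 (0.05 log units; within the scatter). Compound 1 and compound 3 thus cannot be told apart here, although the two groups differ in their atoms and hydrogen-bond acceptors. No measurement at hand offers an explanation for this result. Still open, from the compounds shown here alone, is whether an amine or a carboxylic acid at this place would give a step beyond the scatter. The same question stands for a longer chain there.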